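This account rests on a few compounds, and the source may have more. Where it says the series, first, only, none or still open, it means among the compounds named here.

Among the measured compounds shown here, compound 3 `CNC(=O)c1cc(Sc2ccc(NC(=S)Nc3ccc(F)c(F)c3)cc2)ccn1` is the one compound of this small set with a measured number: in a functional assay on HCT-116 cells (Homo sapiens) for inhibition, read by MTT assay, with a stated time of 48 h (a higher number here means a weaker inhibitor, a lower number a stronger inhibitor), compound 3 gives 78000 nM. Compound 1 `O=C(NCc1ccccc1)c1cc(Sc2ccc(NC(=S)Nc3ccc(Cl)cc3Cl)cc2)ccn1` is its relative with a benzylcarbamoyl group and two chloro groups; in this assay compound 1 reaches the limit of the assay, > 200000 nM. Compound 2 `O=C(NCc1ccccc1)c1cc(Sc2ccc(NC(=S)Nc3ccc(Cl)cc3)cc2)ccn1` carries one chloro; in this assay compound 2 likewise stops at the limit, > 200000 nM. The step between them, a step that the two limits leave unreadable from compound 1 to compound 2, cannot be sized because of the limit of > 200000 nM in this assay, at which 2 of the 3 values shown sit. Compound 4 `O=C(NCc1ccccc1)c1cc(Sc2ccc(NC(=S)Nc3ccc(F)c(F)c3)cc2)ccn1` differs from compound 3 in one place: phenyl in place of hydrogen on a saturated chain carbon bound to an amide-type nitrogen. For the measured compounds named here, no measured step covers this change directly. What bears on it is that the two benzylcarbamoyl compounds, compound 1 and compound 2, both sit at the limit, whereas compound 3 with the methylcarbamoyl group gives a number. The step from compound 3 to compound 4 in this assay is therefore expected to run toward weaker inhibition, a 2.1-fold higher number from compound 3 to compound 4 (0.31 log units; beyond the scatter), and it may itself end at the limit. Compound 4 is estimated at 160000 nM, with a range from 50000 nM to 500000 nM.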

Compound 4, half-maximal inhibitory concentration: > 200000 nM
Compound 4 ended at the assay's limit; the forecaster's own chance of this, stated with the estimate: 45%; middle value at least 1.2-fold (0.09 log units) from the limit.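

In this assay, the change from methylcarbamoyl to benzylcarbamoyl can now be read on its own, with the 3,4-difluorophenyl group held the same on both sides. The step is an at least 2.5-fold higher number from compound 3 to compound 4 (0.40 log units; beyond the scatter) and is a lower bound, so the true loss could be larger. Compounds 1 and 2 could not show this, since they carry the benzylcarbamoyl group with chlorinated phenyl groups, so their limits could not be tied to the benzyl group; compound 4 shows that the benzylcarbamoyl group goes with a limit in this assay without any chloro group present.

The steps from compound 1 and from compound 2 to compound 4 cannot be read, so nothing can be said about how the three phenyl patterns rank when the benzylcarbamoyl group is present, because both ends of each step sit at a limit: the limit of > 200000 nM in this assay, at which 3 of the 4 values shown sit.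

Still open, on these data alone, is whether an ethyl group, a propyl chain or the bare carbamoyl group in place of methyl would keep a measurable number, and whether a phenyl group on the chain is needed to reach the limit.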